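Replacing pyridin-3-yl with 1-hydroxycyclohexyl in compound 3

The source may report more compounds than this note shows. Statements on the series, on what has been measured and on what is new or still open speak of the compounds shown alone.

Measured in a functional assay on MDA-MB-231 cells (Homo sapiens) for antiproliferative activity, read by sulforhodamine B assay, with a stated time of 48 h; on this read-out higher numbers stand for weaker inhibition of growth and lower numbers for stronger inhibition of growth:
compound 1 `Cc1ccc(-c2cn(CCCN3C(=O)COc4ccccc43)nn2)cc1` gives 1120 nM
compound 2 `COc1ccc2cc(-c3cn(CCCN4C(=O)COc5ccccc54)nn3)ccc2c1` gives 5000 nM
compound 3 `O=C1COc2ccccc2N1CCCn1cc(-c2cccnc2)nn1` gives 3000 nM

Compound 3, at 3000 nM, lies within the scatter of compound 2 and sits clearly above compound 1 on this scale. The next structure is compound 4 `O=C1COc2ccccc2N1CCCn1cc(C2(O)CCCCC2)nn1`, and the change is 1-hydroxycyclohexyl in place of pyridin-3-yl on an aromatic carbon. For the measured compounds named here, only one measured step bears on this place, and it is modest: a 2.7-fold higher number from compound 1 to compound 3 (0.43 log units; beyond the scatter). Going by the values given here, it exchanged one aromatic group for another, so no measured compound shows a non-aromatic ring here, and the guidance is weak. The expected result in this assay is therefore no step beyond the scatter: a 1.3-fold higher number from compound 3 to compound 4 (0.12 log units; within the scatter). For compound 4 the estimated value is 4000 nM, with an expected range from 1500 nM to 11000 nM.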

Compound 4, concentration for 50% growth inhibition: 1200 nM
Beside the measured number, compound 4's estimate is 3.3-fold (0.52 log units) above it; measured number below the stated range.
By their numbers in this assay, from the lowest: compounds 1 and 4 (each within the scatter of the next); then compounds 3 and 2 (each within the scatter of the next).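

The earlier compounds shown here carried only aromatic groups at this position, and compound 4 shows that in this assay an aromatic ring is not required there. Replacing pyridin-3-yl with 1-hydroxycyclohexyl gives a 2.5-fold lower number from compound 3 to compound 4 (0.40 log units; beyond the scatter) and this step is beyond the scatter. Set against 4-methylphenyl, the same group gives a 1.1-fold higher number from compound 1 to compound 4 (0.03 log units; within the scatter) and this lies within the scatter, so these two quite different groups cannot be told apart here.

The compounds shown leave open what a plain cyclohexyl group, or an amine in place of the hydroxyl, would give. Nothing available accounts for the step from pyridin-3-yl to 1-hydroxycyclohexyl.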